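This account rests on a few compounds, and the source may have more. Where it says the series, first, only, none or still open, it means among the compounds named here.

Of the compounds shown here, three have been measured in a functional assay on the whole organism for inhibition, with Echinochloa esculenta as the target; on this read-out lower numbers stand for stronger inhibition and higher numbers for weaker inhibition. Compound 1 `Cc1cc(Cl)ccc1/N=c1\sc(=S)n2n1CCCC2` gives 2880 nM, compound 2 `CC(C)Oc1cc(-n2c(=S)n3n(c2=S)CCCC3)c(F)cc1Cl` gives 12.3 nM, and compound 3 `S=c1n(-c2ccc(Cl)cc2)c(=S)n2n1CCCC2` gives 89.1 nM. Compound 3 therefore holds the middle place: its number is higher than that of compound 2 and lower than that of compound 1, and both gaps lie beyond the scatter.

Compound 4 `S=c1n(-c2ccccc2)c(=S)n2n1CCCC2` has not yet been measured. It differs from compound 3 in one place: hydrogen in place of chloro on an aromatic carbon. In words, hydrogen stands in place of chloro on an aromatic carbon, para to a large group. For the measured compounds named here, no pair of measured compounds isolates this change, so the data give no direct size for it. All three measured compounds carry a chloro, and compound 4 would be the first without one, which makes any figure an extrapolation from compound 3 at 89.1 nM.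

A moderate loss of inhibition is expected, probably beyond the scatter, though a smaller change cannot be ruled out. The estimated change is a 5.6-fold higher number from compound 3 to compound 4 (0.75 log units; beyond the scatter), toward a higher number. For compound 4 the expected value is about 500 nM, with an estimated range of 120 nM to 2500 nM.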

Compound 4, half-maximal inhibitory concentration: 3550 nM
Compound 4: middle estimate off by 7.1-fold (0.85 log units), on the low side, outside the stated range (above it).
By their numbers in this assay, from the lowest: compound 2; then compound 3; then compounds 1 and 4 (each within the scatter of the next).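

In this assay, the chloro on the aromatic carbon para to a large group proves to matter a great deal: replacing it with hydrogen gives a 40-fold higher number from compound 3 to compound 4 (1.60 log units; beyond the scatter), a large step that lies beyond the scatter. For the compounds shown here, this is the first size for any single change, since none of the earlier compounds differed from one another in only one place and their gaps could not be assigned to the chloro or to any other group. The step also shows that, on this core, the unsubstituted aromatic ring gives far weaker inhibition than the ring bearing chloro, although no measurement accompanying the step bears on the reason.

With only chloro and hydrogen shown at this position, it remains open whether fluoro, bromo, methyl or methoxy would retain the inhibition seen with chloro. As far as these compounds go, it also remains open whether removing the chloro would cost as much on the aromatic ring of compound 2, which additionally carries fluoro and isopropoxy groups.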